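Side-chain halogen swaps on the shared core: fluoro vs chloro

This account rests on a few compounds, and the source may have more. Where it says the series, first, only, none or still open, it means among the compounds named here.

Compound 1 `O=C(O)/C=C/c1ccc(/C(=C(/CCO)c2ccccc2)c2ccc3[nH]ncc3c2)cc1`: > 1000 nM
Compound 2 `O=C(O)/C=C/c1ccc(/C(=C(/CCF)c2ccccc2)c2ccc3[nH]ncc3c2)cc1`: 2.1 nM
Compound 3 `O=C(O)/C=C/c1ccc(/C(=C(/CCCl)c2ccccc2)c2ccc3[nH]ncc3c2)cc1`: 9 nM

In a functional assay on MCF7 cells (Homo sapiens) for cytotoxicity, read by CellTiter-Glo, with a stated time of 5 days (on this read-out higher numbers stand for weaker inhibition and lower numbers for stronger inhibition), compound 1 gives only a limit, > 1000 nM, not a number (the limit of > 1000 nM in this assay, at which 1 of the 3 values shown sits). Compound 2 gives 2.1 nM and compound 3 gives 9 nM; compound 3 has the highest of the two numbers shown, with a 4.3-fold higher number from compound 2 to compound 3 (0.63 log units; beyond the scatter). Replacing hydroxy gave an at least 470-fold lower number from compound 1 to compound 2 (2.67 log units; beyond the scatter) and an at least 110-fold lower number from compound 1 to compound 3 (2.04 log units; beyond the scatter).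

Compound 4 `O=C(O)/C=C/c1ccc(/C(=C(\c2ccccc2)C(F)F)c2ccc3[nH]ncc3c2)cc1` carries difluoromethyl in place of 2-chloroethyl on a double-bonded chain carbon bound to an aromatic carbon and a double-bonded chain carbon. The halogen steps bear on it: both halogens gave large steps from compound 1, and fluoro gave the modest further gain of a 4.3-fold higher number from compound 2 to compound 3 (0.63 log units; beyond the scatter) read backward. A modest lower number is therefore expected in this assay, within or near the scatter. Compound 4 is estimated at 6 nM, range 1.5 nM to 30 nM, which is the expected step of a 1.5-fold lower number from compound 3 to compound 4 (0.18 log units; within the scatter).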

Compound 4, half-maximal inhibitory concentration: 14 nM
Estimate against measurement, compound 4: 2.3-fold (0.37 log units) below, and the stated range covers the measured number.
By their numbers in this assay, from the lowest: compound 2; then compounds 3 and 4 (each within the scatter of the next). At a limit, above all of these: compound 1.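

In this assay, difluoromethyl in place of 2-hydroxyethyl gives an at least 71-fold lower number from compound 1 to compound 4 (1.85 log units; beyond the scatter), so the gain at this position does not depend on a 2-haloethyl group. That step is read against a limit for compound 1, not a number: the limit of > 1000 nM in this assay, at which 1 of the 4 values shown sits. Difluoromethyl in place of 2-chloroethyl gives a 1.6-fold higher number from compound 3 to compound 4 (0.19 log units; within the scatter), while in place of 2-fluoroethyl it gives a 6.7-fold higher number from compound 2 to compound 4 (0.82 log units; beyond the scatter), so fluorine at this position does not by itself reproduce compound 2.

Open, on these data alone, is how an amine, a methoxy group or a longer chain such as 3-fluoropropyl would read at this position.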